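This account rests on a few compounds, and the source may have more. Where it says the series, first, only, none or still open, it means among the compounds named here.

Compound 1, `CCOC(=O)c1nn(-c2ccccc2)c(-c2ccc(OC)cc2OC)c1C`, gives 4.86% in a functional assay on the whole organism (strain albino) for inhibition, with Rattus norvegicus as the target, read by paw edema, with stated times of 30 min and 2 h, at a dose of 25 mg/kg by the intraperitoneal route; a higher number here means more inhibition at the dose given (going by the name of the read-out), a lower number less inhibition.
Compound 2, `CCOC(=O)c1nn(-c2ccc(Cl)cc2)c(-c2ccc(OC)cc2OC)c1C`, gives 1.43% in this assay.
Compound 3, `CCOC(=O)c1nn(-c2ccc(Cl)cc2)c(-c2ccc(OC)cc2OC)c1-c1ccccc1`, gives 12.7% in this assay.

Compound 2 has the lowest of these three numbers. The step of a number 3.4 percentage points lower from compound 1 to compound 2 (within the scatter) lies within the scatter, so compound 1 and compound 2 cannot be told apart, while the step of a number 11.3 percentage points higher from compound 2 to compound 3 (beyond the scatter) goes beyond it. The compound now to be judged is compound 4, `COc1ccc(-c2c(C)c(C(=O)O)nn2-c2ccc(Cl)cc2)c(OC)c1`. It differs from compound 2 in one place: hydrogen in place of ethyl on an oxygen next to a carbonyl group. Neither measured step touches this part of the molecule: one puts chloro in place of hydrogen on an aromatic carbon, the other phenyl in place of methyl on an aromatic carbon, and both leave the ethoxycarbonyl group as it is. There is thus no measured guide to how an ethoxycarbonyl to carboxy change reads in this assay, and the expectation rests on compound 2 alone, whose value is 1.43%. Compound 4 is therefore expected to show no step beyond the scatter, a number 4.6 percentage points higher from compound 2 to compound 4 (within the scatter). The estimate for compound 4 is 6%, with a range from 0% to 22%.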

Compound 4, a percentage reported as inhibition, in the whole organism at one dose (the size of the read-out at that dose, not a potency): 28.4%
Beside the measured number, compound 4's estimate is 22.4 percentage points below it, outside the stated range (above it).
By their numbers in this assay, from the lowest: compounds 2, 1 and 3 (each within the scatter of the next, the first and the last beyond it); then compound 4.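

Hydrogen in place of ethyl on an oxygen next to a carbonyl group, which turns ethoxycarbonyl into carboxy, gives a number 27 percentage points higher from compound 2 to compound 4 (beyond the scatter) in this assay and so provides the first measured reading of a change at this position. The earlier steps shown here left this group untouched, and this one shows that a single change here can move the read-out beyond the usual scatter. That finding rests on one pair of compounds, so it shows what this change did with the rest of compound 2 held fixed, not a general rule.

As far as these compounds go, it remains open whether an amide or a primary alcohol at this position would read like the carboxy group or like the ethoxycarbonyl group. From the compounds shown here alone, it is also open whether the same change would raise the number in compound 1 or compound 3. Nothing measured here explains why the number rises with this change.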